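This account rests on a few compounds, and the source may have more. Where it says the series, first, only, none or still open, it means among the compounds named here.

Compound 1, `O=C(CN1CCN(c2ccccc2)CC1)N1CCN(c2nnc(-c3ccccc3)c(-c3ccccc3)n2)CC1`: > 963000 nM
Compound 2, `COc1ccccc1N1CCN(CC(=O)N2CCN(c3nnc(-c4ccccc4)c(-c4ccccc4)n3)CC2)CC1`: 167000 nM

In a functional assay on MCF7 cells (Homo sapiens) for cytotoxicity, read by MTT assay, with a stated time of 24 h (on this read-out lower numbers stand for stronger inhibition and higher numbers for weaker inhibition), compound 1 gives > 963000 nM, a limit of the assay rather than a number. Compound 2 reaches 167000 nM. Among the measured compounds shown here, the single measured step, an at least 5.7-fold lower number from compound 1 to compound 2 (0.76 log units; beyond the scatter), is known only as a minimum because compound 1 sits at the limit of > 963000 nM in this assay, at which 1 of the 2 values shown sits. Compound 3, `O=C(CN1CCN(c2cccc(Cl)c2)CC1)N1CCN(c2nnc(-c3ccccc3)c(-c3ccccc3)n2)CC1`, differs from compound 1 by chloro in place of hydrogen on an aromatic carbon. For the measured compounds named here, no measured step covers chloro, so the methoxy step is only a loose guide, and another limit cannot be excluded. For compound 3 the expected step is an at least 2.7-fold lower number from compound 1 to compound 3 (0.43 log units; beyond the scatter), giving an estimate of 350000 nM, between 120000 nM and 1200000 nM.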

Compound 3, half-maximal inhibitory concentration: 56300 nM
Beside the measured number, compound 3's estimate is 6.2-fold (0.79 log units) above it; the measured number lies below the stated range.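

In this assay, a chloro on the ring, meta to a large group, is enough on its own for a large step, an at least 17-fold lower number from compound 1 to compound 3 (1.23 log units; beyond the scatter). Swapping the 2-methoxyphenyl for 3-chlorophenyl adds a further modest step, a 3.0-fold lower number from compound 2 to compound 3 (0.47 log units; beyond the scatter). The first step remains a minimum because compound 1 gives only a limit of the assay: the limit of > 963000 nM in this assay, at which 1 of the 3 values shown sits.

The compounds shown do not separate the chloro itself from its place on the ring. On these data alone, how a fluoro, a methyl or an amine would compare at that place remains open.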